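From Phenoxy to Amino on a Pyrimidine-Bearing Core

A few compounds are considered here, and "the series" means these few. Any claim that something is new, unique, unknown or untested is made for them only; others in the source may bear on it.

In a functional assay on A-431 cells (Homo sapiens) (a lower number here means that less compound is needed, a higher number that more compound is needed for the effect), compound 3 `COc1cc(OC)cc(Oc2ncncc2-c2n[nH]c(Nc3ccc4c(c3)OCCO4)n2)c1` gives 44 nM and compound 2 `COc1cc(Nc2n[nH]c(-c3cccnc3Oc3cc(OC)cc(OC)c3)n2)cc(OC)c1` gives 23 nM, so these two values lie within the scatter of each other. Compound 1 `COc1cc(Nc2ncccc2-c2nc(Nc3cc(OC)ccc3OC)n[nH]2)cc(OC)c1` reaches only a limit of the assay, > 10000 nM. Compound 4 `COc1cc(Nc2ncncc2-c2n[nH]c(Nc3ccc4c(c3)OCCO4)n2)cc(OC)c1` has not yet been measured. It arises from compound 3 by one change: (3,5-dimethoxyphenyl)amino in place of 3,5-dimethoxyphenoxy on an aromatic carbon. (3,5-dimethoxyphenyl)amino takes the place of 3,5-dimethoxyphenoxy on an aromatic carbon of a six-membered aromatic ring with 2 nitrogen. Going by the values given here, no pair of measured compounds shows this change alone, so the expectation is uncertain. Among the compounds with values here, compound 1 is the only measured compound carrying (3,5-dimethoxyphenyl)amino on its core, and its reading of > 10000 nM is a limit. A clear move towards a higher number in this assay is therefore expected, well beyond the scatter. The expected step is an 18-fold higher number from compound 3 to compound 4 (1.26 log units; beyond the scatter). For compound 4 the estimated value is 800 nM, with an expected range from 60 nM to 10000 nM.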

Compound 4, half-maximal effective concentration: 53 nM
Compound 4: middle estimate off by 15-fold (1.18 log units), on the high side, and the stated range ends above it.
By their numbers in this assay, from the lowest: compounds 2, 3 and 4 (each within the scatter of the next, the first and the last beyond it). At a limit, above all of these: compound 1.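

In this assay, putting (3,5-dimethoxyphenyl)amino in place of 3,5-dimethoxyphenoxy on this aromatic carbon gives a 1.2-fold higher number from compound 3 to compound 4 (0.08 log units; within the scatter), so at this position the exchange of the two groups leaves no readable difference, although only the entering group carries a hydrogen-bond donor. Compound 4, at 53 nM, also shows that (3,5-dimethoxyphenyl)amino on a core does not by itself bring a compound to the reading of compound 1. Compound 1 differs from compound 4 in more than one place, and its reading is a limit, not a number: the limit of > 10000 nM in this assay, at which 1 of the 4 values shown sits.

Which of those differences goes with the limit stays open. So does whether a methylamino link, a thioether or a methylene link in the same place would hold the number in this assay.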